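Second methoxy on compound 2: expected effect on alpha-glucosidase

This account rests on a few compounds, and the source may have more. Where it says the series, first, only, none or still open, it means among the compounds named here.

In an assay on isolated protein for inhibition of lysosomal alpha-glucosidase (Rattus norvegicus), read by colorimetric assay (on this read-out higher numbers stand for weaker inhibition and lower numbers for stronger inhibition), compound 2 `COc1ccc([C@]2(CO)NC[C@@H](O)[C@@H]2O)cc1` gives 395000 nM, the highest of the three numbers. Compound 1 `OC[C@@]1(c2ccc(F)cc2)NC[C@@H](O)[C@@H]1O` gives 12000 nM and compound 3 `COc1ccc([C@@]2(CO)NC[C@H](O)[C@H]2O)cc1` gives 2100 nM. The step of a 33-fold higher number from compound 1 to compound 2 (1.52 log units; beyond the scatter) and the step of a 190-fold lower number from compound 2 to compound 3 (2.27 log units; beyond the scatter) are both large, the latter resting on (the fact that compounds 2 and 3 differ only in the configuration as drawn). Compound 4 `COc1ccc([C@]2(CO)NC[C@@H](O)[C@@H]2O)cc1OC` differs from compound 2 by methoxy in place of hydrogen on an aromatic carbon. Neither measured step concerns a second methoxy, so no direction is supported; a step within the scatter, or a modest one either way, is the expectation in this assay. For compound 4 the expected value is 400000 nM, ranging from 80000 nM to 2000000 nM, meaning an expected step of a 1.0-fold higher number from compound 2 to compound 4 (0.01 log units; within the scatter).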

Compound 4, half-maximal inhibitory concentration: 105000 nM
Beside the measured number, compound 4's estimate is 3.8-fold (0.58 log units) above it; the measured number falls inside the stated range.
By their numbers in this assay, from the lowest: compound 3; then compound 1; then compound 4; then compound 2.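

In this assay the step of a 3.8-fold lower number from compound 2 to compound 4 (0.58 log units; beyond the scatter) is modest but beyond the scatter: a methoxy in place of hydrogen, ortho to the existing methoxy, lowers the number rather than raising it. Earlier steps exchanged a ring substituent or inverted the configuration; this one shows that adding to the aromatic ring at this position is tolerated. Nothing shown bears on the reason for this step. As far as these compounds go, whether a hydroxyl or an amine at this position would lower the number likewise remains open, as does the effect of this second methoxy in the mirror-image series of compound 3.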